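The compounds below may be only part of what the source reports. "The series", "measured", "known", "first", "only" and "open" are said of these compounds alone.

Measured in a functional assay on Rec1 cells (Homo sapiens) for inhibition, read by luminescence and CellTiter-Glo, with a stated time of 72 h; on this read-out lower numbers stand for stronger inhibition and higher numbers for weaker inhibition:
Compound 1 `O=C(CCl)N1CCCC(n2nc(-c3ccc(Oc4ccccc4)cc3)cc2CO)C1`: 400 nM
Compound 2 `C=CC(=O)Nc1ccc(Cn2nc(-c3ccc(Oc4ccccc4)cc3)cc2C(=O)O)cc1`: > 60000 nM
Compound 3 `C/C=C/C(=O)Nc1cccc(Cn2nc(-c3ccc(Oc4ccccc4)cc3)cc2C(=O)O)c1`: 26000 nM

Compound 2 stands at > 60000 nM in this assay, and this is a limit of the assay, not a number. Its exact position is therefore unknown, so any step away from it can only be judged loosely.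

Compound 4 `C=CC(=O)Nc1ccc(Cn2nc(-c3ccc(Oc4ccccc4)cc3)cc2C(=O)OCC)cc1` has not yet been measured. It comes from compound 2 by a single change, ethyl in place of hydrogen on an oxygen next to a carbonyl group, which turns carboxy into ethoxycarbonyl.

Among the measured compounds shown here, no measured pair in this set isolates that change, so the expectation rests on a broader contrast. Compound 3, which also carries a carboxy group, gives 26000 nM, whereas compound 1, which has none, gives 400 nM. Compound 1 also differs from the others elsewhere, so this is only a rough guide. Even so, a clear step toward stronger inhibition in this assay is expected, well beyond the usual scatter. The estimated change is an at least 15-fold lower number from compound 2 to compound 4 (1.17 log units; beyond the scatter). Compound 4 is expected at 4000 nM, with an estimated range of 600 nM to 25000 nM.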

Compound 4, half-maximal inhibitory concentration: 2800 nM
Beside the measured number, compound 4's estimate is 1.4-fold (0.15 log units) above it, and the stated range covers the measured number.
By their numbers in this assay, from the lowest: compound 1; then compound 4; then compound 3. At a limit, above all of these: compound 2.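

Among the compounds shown here, the pair compound 2 and compound 4 is the first in the set that differs in one place only, and it isolates the change from carboxy to ethoxycarbonyl, which none of the earlier compounds could do. In this assay, ethyl in place of hydrogen on this oxygen gives an at least 21-fold lower number from compound 2 to compound 4 (1.33 log units; beyond the scatter), so at this position on the shared core the carboxy group can be replaced with a gain beyond the scatter. For compound 2, > 60000 nM is a limit of the assay and not a number, so the step fixes only the smallest possible size of the change and its true size stays unknown: the limit of > 60000 nM in this assay, at which 1 of the 4 values shown sits.

The compounds shown leave open whether a methyl group or a longer chain such as butyl on the same oxygen, or an amide in place of the carboxy group, would move the number further in either direction. They also leave open whether the same change would carry over to compound 3, which has the carboxy group as well and gives 26000 nM.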